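Methoxy removal on the pyrazole-borne aryl ring: carrying a step over

The source may report more compounds than this note shows. Statements on the series, on what has been measured and on what is new or still open speak of the compounds shown alone.

Compound 1 `COc1cc(-c2cc(/C=C/C(=O)c3ccc(N)cc3)[nH]n2)cc(OC)c1OC` and compound 2 `COc1ccc(-c2cc(/C=C/C(=O)c3ccc(N)cc3)[nH]n2)cc1OC` share a core; compound 3 `COc1cc(C(=O)/C=C/c2cc(-c3cc(OC)c(OC)c(OC)c3)n[nH]2)cc(OC)c1OC` and compound 4 `COc1ccc(-c2cc(/C=C/C(=O)c3cc(OC)c(OC)c(OC)c3)[nH]n2)cc1OC` share another, and the difference between the two cores is not broken down here. In a functional assay on HT-29 cells (Homo sapiens) for inhibition, read by sulforhodamine B assay, with a stated time of 48 h (a higher number here means a weaker inhibitor of growth, a lower number a stronger inhibitor of growth), compound 1 gives 1850 nM and compound 2 gives 2600 nM; the change between them is hydrogen in place of methoxy on an aromatic carbon and the step is a 1.4-fold higher number from compound 1 to compound 2 (0.15 log units; within the scatter). The change from compound 3 to compound 4 is hydrogen in place of methoxy on an aromatic carbon, the same change in the same place. In this assay compound 3 gives 1790 nM. The step from compound 3 to compound 4 is expected to be a 1.4-fold higher number from compound 3 to compound 4 (0.15 log units; within the scatter), resting on the earlier step of a 1.4-fold higher number from compound 1 to compound 2 (0.15 log units; within the scatter) and likely within the scatter. Compound 4 is therefore estimated at 2500 nM in this assay, expected between 1200 nM and 5500 nM.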

Compound 4, concentration for 50% growth inhibition: 1300 nM
Compound 4: middle estimate off by 1.9-fold (0.28 log units), on the high side; the range from low to high includes it.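

In this assay, hydrogen in place of methoxy gives a 1.4-fold lower number from compound 3 to compound 4 (0.14 log units; within the scatter), so on the core of compound 3, as on the core of compound 1, the step stays within the scatter. Set side by side, the two steps do not differ: the same change on two cores in this assay, a 1.4-fold higher number (0.15 log units; within the scatter) from compound 1 to compound 2 and a 1.4-fold lower number (0.14 log units; within the scatter) from compound 3 to compound 4, 1.9-fold (0.29 log units) apart, within the scatter of two such steps. This supports carrying the change between these two cores only as a step within the scatter; it gives the step no reliable direction and says nothing about any further core.

Open, going by these compounds, is whether a different group at this place, such as a hydroxyl, a chlorine or a longer alkoxy chain, would give a step beyond the scatter. Also open, on these data alone, is what removing a further methoxy from the same ring would do.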